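Pyridin-4-yl in Place of Methyl on the Shared Core

The compounds below may be only part of what the source reports. "The series", "measured", "known", "first", "only" and "open" are said of these compounds alone.

Measured compounds:
Compound 1, `CO[C@@H]1CC=C2NN(c3ccc(C)cc3)C(=O)C[C@]2(C)O1`: 21500 nM
Compound 2, `CO[C@@H]1CC=C2NN(c3cc4ccccc4[nH]3)C(=O)C[C@]2(C)O1`: 3920 nM

Of the compounds shown here, two have been measured in a functional assay on A549 cells (Homo sapiens) for inhibition, read by sulforhodamine B assay, with a stated time of 48 h; a higher number here means a weaker inhibitor, a lower number a stronger inhibitor. Compound 1, `CO[C@@H]1CC=C2NN(c3ccc(C)cc3)C(=O)C[C@]2(C)O1`, gives 21500 nM in this assay. Compound 2, `CO[C@@H]1CC=C2NN(c3cc4ccccc4[nH]3)C(=O)C[C@]2(C)O1`, gives 3920 nM in this assay, the lowest of the two numbers and therefore the stronger inhibitor; the gap to compound 1 lies beyond the usual scatter of repeated measurements.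

Compound 3, `CO[C@@H]1CC=C2NN(c3cc4ccccc4[nH]3)C(=O)C[C@]2(c2ccncc2)O1`, has not yet been measured. It differs from compound 2 in one place: pyridin-4-yl in place of methyl on a saturated ring carbon. Among the compounds with values here, no step between measured compounds of this kind exists here, so nothing shows how this assay answers a change on a saturated ring carbon of the shared core. The expectation is therefore cautious: a step of moderate size, in either direction, cannot be ruled out, and a result within the scatter of compound 2 is as likely as any other.

On that basis compound 3 is expected to give about 3000 nM in this assay, with a range from 600 nM to 15000 nM. This estimate corresponds to an expected step of a 1.3-fold lower number from compound 2 to compound 3 (0.12 log units; within the scatter), which is small against the uncertainty of the guess.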

Compound 3, half-maximal inhibitory concentration: 4050 nM
Compound 3: the middle estimate sits 1.4-fold (0.13 log units) below what was measured; low and high end bracket the measured number.
By their numbers in this assay, from the lowest: compounds 2 and 3 (each within the scatter of the next); then compound 1.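

Replacing the methyl on the saturated ring carbon next to the ring oxygen with pyridin-4-yl raises the group from one heavy atom to six and adds a six-membered aromatic ring and a hydrogen-bond acceptor, yet this assay shows a 1.0-fold higher number from compound 2 to compound 3 (0.01 log units; within the scatter) and so does not tell these two compounds apart. This is the only step shown at this position, and it shows that a much larger ring-bearing group can stand where the methyl stood without a difference in this cell assay that rises above the scatter. Nothing measured here explains this result, and no separate data on the properties of these compounds or how they act are available.

A single step cannot show whether this position is insensitive to change in general or whether these two groups merely happen to give matching numbers. Phenyl on the same carbon would test whether the ring nitrogen of pyridin-4-yl matters, while an amine, a carboxylic acid or a longer alkyl chain there would show whether groups of a different kind are accepted as well.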